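The source may report more compounds than this note shows. Statements on the series, on what has been measured and on what is new or still open speak of the compounds shown alone.

Measured in a functional assay on the whole organism (strain Wistar albino) for inhibition, with Rattus norvegicus as the target, read by paw edema, with stated times of 1 h and 2 h, at a dose of 0.32 mmol/kg by the intraperitoneal route (on this read-out higher numbers stand for more inhibition at the one dose given (going by the name of the read-out) and lower numbers for less inhibition), so far:

compound 1 `Cc1ccc(-c2nn(-c3ccc(Cl)cc3)cc2C(CC(=O)c2ccc(Cl)cc2)C(=O)c2ccc(F)cc2)cc1`: 25.9%
compound 2 `COc1ccc(C(=O)C(CC(=O)c2ccc(Cl)cc2)c2cn(-c3ccc(Cl)cc3)nc2-c2ccc(C)cc2)cc1`: 16.1%
compound 3 `Cc1ccc(-c2nn(-c3ccc(S(N)(=O)=O)cc3)cc2-c2cc(-c3ccc(Cl)cc3)[nH]c2-c2ccc(F)cc2)cc1`: 75.4%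

Compound 1 and compound 2 share one core and differ in a single place, (methoxy in place of fluoro on an aromatic carbon). In this assay this change gives a number 9.8 percentage points lower from compound 1 to compound 2 (within the scatter), so the two values cannot be told apart.

Compound 3 stands on a different core; how the two cores differ is not broken down here. In this assay compound 3 gives 75.4%, the highest of the three values, and its distance to compound 1 as well as to compound 2 is beyond the scatter, so its number in this assay is the highest of the measured compounds.

Compound 4 `COc1ccc(-c2[nH]c(-c3ccc(Cl)cc3)cc2-c2cn(-c3ccc(S(N)(=O)=O)cc3)nc2-c2ccc(C)cc2)cc1` has not been measured. It differs from compound 3 by methoxy in place of fluoro on an aromatic carbon. The place of this change reads the same, word for word, as the change from compound 1 to compound 2, so it is taken as the same change; read one bond further out, the ring in compound 1 carries a carbonyl and the ring in compound 3 does not.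

Because the earlier occurrence gave a number 9.8 percentage points lower from compound 1 to compound 2 (within the scatter), a step of about the same small size is expected here, a number 7.4 percentage points lower from compound 3 to compound 4 (within the scatter), within the scatter. Compound 4 is therefore estimated in this assay at 68%, with the likely range from 52% to 82%.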

Compound 4, a percentage reported as inhibition, in the whole organism at one dose (the size of the read-out at that dose, not a potency): 49.7%
For compound 4 the middle estimate is 18.3 percentage points above the measured one; the measured number lies below the stated range.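

On the core of compound 3, methoxy in place of fluoro on an aromatic carbon gives a number 25.7 percentage points lower from compound 3 to compound 4 (beyond the scatter). Set beside the earlier occurrence, this change does not keep its size from one core to the other in this assay: the same change on two cores in this assay, a number 9.8 percentage points lower (within the scatter) from compound 1 to compound 2 and a number 25.7 percentage points lower (beyond the scatter) from compound 3 to compound 4, 15.9 percentage points apart, beyond the scatter of two such steps. A step read on one core in this series is therefore a poor guide to the size of the same step on the other, but two pairs at a single dose give no general rule and do not show which of the differences between the two cores accounts for the gap.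

The compounds shown leave open how the 4-position of this phenyl ring would respond on the core of compound 3 to groups other than fluoro and methoxy, such as an amine, a carboxylic acid or a longer alkoxy chain. Also open, going by these compounds, is whether the same change on a third core would come closer to the step on the core of compound 1 or to the step on the core of compound 3, and whether the gap between the two steps would persist at another dose.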